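Ethoxy in place of ethyl on an amide-type nitrogen

This account rests on a few compounds, and the source may have more. Where it says the series, first, only, none or still open, it means among the compounds named here.

In an ADME assay on microsomes from liver (Homo sapiens) for metabolic stability (on this read-out lower numbers stand for slow clearance and higher numbers for fast clearance), compound 3 `CCN(C)C(=O)c1n[nH]c2c1CN(C(=O)Nc1cccc(Cl)c1)CC2` gives 87 mL/min/kg. This lies within the usual scatter of compound 1 `CC(C)ON(C)C(=O)c1n[nH]c2c1CN(C(=O)Nc1cccc(Cl)c1)CC2`, which gives 65 mL/min/kg, while compound 2 `O=C(Nc1cccc(Cl)c1)N1CCc2[nH]nc(C(=O)N3CCCCO3)c2C1` gives 38 mL/min/kg. Compound 4 `CCON(C)C(=O)c1n[nH]c2c1CN(C(=O)Nc1cccc(Cl)c1)CC2` carries one change from compound 3: ethoxy in place of ethyl on an amide-type nitrogen. The closest measured comparison is a 1.3-fold higher number from compound 1 to compound 3 (0.13 log units; within the scatter), where ethyl replaces isopropoxy. The larger step, a 2.3-fold higher number from compound 2 to compound 3 (0.36 log units; beyond the scatter), replaces a ring-bearing group and so bears less directly. On that evidence, the expected change in this assay is small, and the expected step is a 1.4-fold lower number from compound 3 to compound 4 (0.15 log units; within the scatter). For compound 4 the estimate is 62 mL/min/kg, with an expected range of 38 mL/min/kg to 95 mL/min/kg.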

Compound 4, clearance: 55 mL/min/kg
Estimate against measurement, compound 4: 1.1-fold (0.05 log units) above, and the stated range covers the measured number.
By their numbers in this assay, from the lowest: compounds 2, 4, 1 and 3 (each within the scatter of the next, the first and the last beyond it).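

In this assay, ethoxy in place of ethyl on the amide-type nitrogen gives (a 1.6-fold lower number from compound 3 to compound 4 (0.20 log units; within the scatter)), so adding this oxygen keeps the number within the scatter. Ethoxy in place of isopropoxy gives (a 1.2-fold lower number from compound 1 to compound 4 (0.07 log units; within the scatter)), and the open-chain group in place of the ring-bearing group gives (a 1.4-fold higher number from compound 2 to compound 4 (0.16 log units; within the scatter)), so the ethoxy compound lies within the scatter of all three others. No measurement here explains these steps.

On these data alone, whether methoxy on this nitrogen would stay within the scatter remains open, as does whether a longer chain such as butoxy would.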